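The source may hold more compounds than are shown below. What is called first, only, known or untested is meant among the compounds shown, and "the series" means these compounds.

Of the compounds shown here, two have been measured in an assay on HEK293 cells for activation of Kir3.1/Kir3.2 (Homo sapiens), read by thallium flux; on this read-out lower numbers stand for smaller maximal responses and higher numbers for larger maximal responses. Compound 1, with structure `CC1CC1c1cc(NC(=O)Cn2nnc(-c3ccccc3)n2)n(C2CCCCC2)n1`, gives 78% in this assay. Compound 2, with structure `Cc1cc(NC(=O)Cn2nnc(-c3cccnc3)n2)n(C2CCCCC2)n1`, gives 96% in this assay, the higher of the two values shown. The gap between compound 2 and compound 1 lies beyond the usual scatter of repeated measurements.

Compound 3, with structure `Cc1cc(NC(=O)Cn2nnc(-c3cccc(F)n3)n2)n(C2CCCCC2)n1`, has not yet been measured in this assay. It differs from compound 2 in one place: 6-fluoropyridin-2-yl in place of pyridin-3-yl on an aromatic carbon. Going by the values given here, no measured pair in this set shows how this kind of exchange shifts the maximal response, so the expectation rests on compound 2 alone and on the modest size of the change.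

A small downward step, or none beyond the scatter, is expected, meaning a shift of a number 10 percentage points lower from compound 2 to compound 3 (within the scatter) in this assay. Compound 3 is thus expected to reach 86% in this assay, within a range from 66% to 102%.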

Compound 3, largest response reached (Emax), in percent of the reference or control that the assay uses: > 83%
Compound 3: only a limit was reported; the forecaster's own chance of this, stated with the estimate: 0%; the middle value does not contradict the limit.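

Compound 3 is reported only as a limit, > 83%, and not as a number. Going by these compounds alone, no step from compound 2 to compound 3 can be read. The compounds shown leave open whether 6-fluoropyridin-2-yl in place of pyridin-3-yl changes the maximal response at all, and in which direction.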